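Purine Ribosides as Inhibitors of the Nucleoside Transporter

This account rests on a few compounds, and the source may have more. Where it says the series, first, only, none or still open, it means among the compounds named here.

Compound 1: `O=[N+]([O-])c1ccc2c(c1)CN(c1ncnc3c1nc1n3[C@@H]3O[C@H](CO1)[C@@H](O)[C@H]3O)CC2` gives 331 nM
Compound 2: `OC[C@H]1O[C@@H](n2cnc3c(NCc4ccco4)ncnc32)[C@H](O)[C@@H]1O` gives 36300 nM
Compound 3: `CCCC(C)n1cnc2c(SCc3ccccn3)nc(N)nc21` gives 41700 nM

The three measured compounds were tested in an assay on isolated protein for binding affinity to Equilibrative nucleoside transporter 1 (Homo sapiens); a higher number here means a weaker inhibitor, a lower number a stronger inhibitor. Compound 2 stands second highest of the three numbers. Its nearest neighbour is compound 3, which gives 41700 nM, a difference that lies within the scatter, so the two cannot be ordered. Compound 1 stands far from both, with a number that lies beyond the scatter below that of compound 2.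

The unmeasured compound 4, `OC[C@H]1O[C@@H](n2cnc3c(CSc4cccc(I)c4)ncnc32)[C@H](O)[C@@H]1O`, shares the ribose-bearing core of compound 2 but differs at one place: a group of 9 heavy atoms (7 carbon, 1 sulfur, 1 iodine; one six-membered aromatic ring of carbon only) in place of a group of 7 heavy atoms (5 carbon, 1 nitrogen, 1 oxygen; one five-membered aromatic ring with 1 hetero atom), on an aromatic carbon. The group that leaves carries the hydrogen-bond donor of compound 2; the group that enters, a sulfur-linked iodophenyl chain, brings none.

For the measured compounds named here, no step between measured compounds is known here, so the expectation for compound 4 rests on the spread of the three numbers alone. The step from compound 2 to compound 4 is expected to be a move toward a lower number, beyond the scatter, as a 12-fold lower number from compound 2 to compound 4 (1.08 log units; beyond the scatter). Compound 4 is therefore estimated at 3000 nM, within a range from 300 nM to 30000 nM.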

Compound 4, half-maximal inhibitory concentration: 245 nM
Compound 4: middle estimate off by 12-fold (1.09 log units), on the high side, and the stated range ends above it.
By their numbers in this assay, from the lowest: compounds 4 and 1 (each within the scatter of the next); then compounds 2 and 3 (each within the scatter of the next).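

With the ribose-bearing core held fixed, replacing ((furan-2-yl)methyl)amino on the aromatic carbon next to the ring nitrogen gives a 150-fold lower number from compound 2 to compound 4 (2.17 log units; beyond the scatter) in this assay, showing that the number responds strongly to the group at this position. The earlier compounds shown here could not show this, since no two of them were linked by a change in one place. The step also shows that a low number here does not require a hydrogen-bond donor in this group, as the entering group, with its six-membered aromatic ring of carbon only, its sulfur and its iodine, has none, while the group that leaves has one.

No measurement shown here explains why the number falls so far. Because the ring, the chain and the iodine all change in this single step, the compounds shown leave open which part carries the effect, and whether the step would hold with chlorine or hydrogen in place of the iodine, with oxygen in place of the sulfur, or with an amine in the chain.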